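The source may hold more compounds than are shown below. What is called first, only, known or untested is meant among the compounds shown, and "the series" means these compounds.

Compound 2 `NCc1cc(O[C@@H]2CCCN(C(=O)Nc3ccccc3)C2)nc(C(F)(F)F)c1` has "not determined" (no result reported) in an ADME assay on the whole organism (plasma, Mus musculus) for pharmacokinetics, read by LC-MS, at a dose of 30 mg/kg by the oral route; a higher number here means more compound in the circulation at the dose given, a lower number less compound in the circulation. Compound 4 `NCc1cc(O[C@H]2CCCN(C(=O)Nc3ccccc3)C2)nc(C(F)(F)F)c1` is its counterpart: the two compounds have the same atoms and bonds and differ only in configuration as drawn: 1 of 1 stereo elements differ; a stereocentre at a saturated ring carbon is drawn R in compound 2 and S in compound 4. Two related compounds do carry numbers. Compound 1 `NCc1cc(Oc2cccc(C(=O)NCCn3cnnn3)c2)nc(C(F)(F)F)c1` gives 1990 nM in this assay, and compound 3 `NCc1cc(Oc2cccc(C(=O)Nc3ccccc3)c2)nc(C(F)(F)F)c1` gives 860 nM. Within the data shown here, the one measured step, a 2.3-fold lower number from compound 1 to compound 3 (0.36 log units; beyond the scatter), concerns a change on an amide-type nitrogen, not the stereocentre at a saturated ring carbon, so it does not bear on the change from compound 2 to compound 4. Among the measured compounds shown here, with no step that touches this difference and no number for compound 2, the direction of any change is open. Compound 4 is therefore expected to lie near the measured compounds, at an estimated 1000 nM, with a range from 200 nM to 5000 nM.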

Compound 4, maximal plasma concentration: 1900 nM
Compound 4: the middle estimate sits 1.9-fold (0.28 log units) below what was measured; the measured number falls inside the stated range.
By their numbers in this assay, from the lowest: compound 3; then compounds 4 and 1 (each within the scatter of the next).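

Among these compounds, compound 2 carries no number in this assay, and no step from compound 2 to compound 4 can be read. The compounds shown leave open whether the configuration at the saturated ring carbon shifts this number at all.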